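Heteroaryl in place of fluorophenyl on the amine-bound carbon

The source may report more compounds than this note shows. Statements on the series, on what has been measured and on what is new or still open speak of the compounds shown alone.

Measured in an assay on HEK293 cells for displacement of a labelled ligand from adenosine receptor A2b (Homo sapiens); a higher number here means a weaker inhibitor, a lower number a stronger inhibitor:
compound 1 `Cn1c(=O)c2[nH]c(-c3ccc(S(=O)(=O)N4CCN(Cc5ccc(Br)cc5)CC4)cc3)cc2n(C)c1=O` gives 1 nM
compound 2 `Cn1c(=O)c2[nH]c(-c3ccc(S(=O)(=O)N4CCN(Cc5ccc(F)cc5)CC4)cc3)cc2n(C)c1=O` gives 10 nM
compound 3 `Cn1c(=O)c2[nH]c(-c3ccc(S(=O)(=O)NC4CCN(Cc5ccccc5)CC4)cc3)cc2n(C)c1=O` gives 43 nM

Compound 2 holds the second highest of the three numbers, between compound 1 and compound 3. Going by the values given here, the only single-point step among them is a 10-fold higher number from compound 1 to compound 2 (1.00 log units; beyond the scatter); compound 3 differs from compound 2 in more than one place, so its higher number cannot be tied to one change.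

Compound 4 `Cn1c(=O)c2[nH]c(-c3ccc(S(=O)(=O)N4CCN(Cc5ccncc5)CC4)cc3)cc2n(C)c1=O` carries pyridin-4-yl in place of 4-fluorophenyl on a saturated chain carbon bound to an amine nitrogen in a ring. Among the compounds with values here, no measured step exchanges a carbon-only ring for one with a hetero atom, so nothing here speaks to it directly; the halogen step above is of a different kind. In this assay a modest step is expected, more likely toward a higher number than a lower one, a 2.0-fold higher number from compound 2 to compound 4 (0.30 log units; within the scatter). Compound 4 is estimated at 20 nM, within 5 nM to 80 nM.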

Compound 4, half-maximal inhibitory concentration: 27 nM
Compound 4: the middle estimate sits 1.4-fold (0.13 log units) below what was measured; the measured number falls inside the stated range.
By their numbers in this assay, from the lowest: compound 1; then compound 2; then compounds 4 and 3 (each within the scatter of the next).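

In this assay, pyridin-4-yl in place of 4-fluorophenyl on the saturated chain carbon bound to the amine nitrogen in the ring gives a 2.7-fold higher number from compound 2 to compound 4 (0.43 log units; beyond the scatter) and shows that a ring with a hetero atom is carried here at a modest cost. Set against 4-bromophenyl, the same ring gives a 27-fold higher number from compound 1 to compound 4 (1.43 log units; beyond the scatter) as a large step, so the aromatic group at this place spans a wider range than the halogen exchange alone showed. No evidence on hand accounts for either step.

On these data alone, whether the ring nitrogen or the loss of fluorine drives the change stays open, and an unsubstituted phenyl at this place would separate the two. As far as these compounds go, how pyridin-3-yl or 4-chlorophenyl would read here also remains open.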